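A few compounds are considered here, and "the series" means these few. Any claim that something is new, unique, unknown or untested is made for them only; others in the source may bear on it.

Compound 1 `CCC(NC(=O)c1ccc(C(=N)N)cc1)C(C)(C)C(=O)N1CCC(CC(=O)O)CC1` carries ethyl on the saturated chain carbon bound to an amide-type nitrogen and a saturated chain carbon. In an in vivo ADME assay on the whole organism (Cavia porcellus) (on this read-out lower numbers stand for a shorter-lived compound and higher numbers for a longer-lived compound), compound 1 gives 1.3 h, the highest of the three numbers, with both others inside the scatter of it. Compound 2 `CC(C)(C(=O)N1CCC(CC(=O)O)CC1)C(CCc1ccccc1)NC(=O)c1ccc(C(=N)N)cc1` gives 0.767 h in this assay, and compound 3 `CC(C)(C(=O)N1CCC(CC(=O)O)CC1)C(NC(=O)c1ccc(C(=N)N)cc1)c1ccc2ccccc2c1` gives 0.85 h. Compound 4 `CC(C)(C(=O)N1CCC(CC(=O)O)CC1)C(NC(=O)c1ccc(C(=N)N)cc1)c1ccc(Cl)cc1` differs from compound 1 in one place: 4-chlorophenyl in place of ethyl on a saturated chain carbon bound to an amide-type nitrogen and a saturated chain carbon. Among the measured compounds shown here, the steps that bear on this change are a 1.5-fold lower number from compound 1 to compound 3 (0.18 log units; within the scatter) and a 1.7-fold lower number from compound 1 to compound 2 (0.23 log units; within the scatter), both within the scatter, as is a 1.1-fold higher number from compound 2 to compound 3 (0.04 log units; within the scatter). No step beyond the scatter is therefore expected in this assay for compound 4, and the expected step is a 1.4-fold lower number from compound 1 to compound 4 (0.16 log units; within the scatter). Compound 4 is estimated at 0.9 h, with a range from 0.45 h to 1.8 h.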

Compound 4, half-life: 1.2 h
Compound 4: the middle estimate sits 1.3-fold (0.12 log units) below what was measured; the range from low to high includes it.
By their numbers in this assay, from the lowest: compounds 2, 3, 4 and 1 (each within the scatter of the next).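

In this assay, the step to a ring on this carbon stays small even with 4-chlorophenyl in place of ethyl, at a 1.1-fold lower number from compound 1 to compound 4 (0.03 log units; within the scatter). The other two steps, a 1.4-fold higher number from compound 3 to compound 4 (0.15 log units; within the scatter) and a 1.6-fold higher number from compound 2 to compound 4 (0.19 log units; within the scatter), also leave 4-chlorophenyl, naphthalen-2-yl and phenethyl unseparated at this position. Nothing available explains these results. As far as these compounds go, whether an amine or a carboxylic acid on this saturated chain carbon would give a step beyond the scatter remains open. So does the effect of a different group in place of the chlorine on the phenyl ring.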